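Chloro for fluoro on two cores in the growth assay

This account rests on a few compounds, and the source may have more. Where it says the series, first, only, none or still open, it means among the compounds named here.

In a functional assay on DU-145 cells (Homo sapiens) for inhibition, read by trypan blue exclusion, with a stated time of 96 h (a higher number here means a weaker inhibitor of growth, a lower number a stronger inhibitor of growth), compound 2 `O=C(/C(=C\c1ccc(F)cc1)S(=O)(=O)c1ccc(Br)cc1)c1ccc(Br)cc1` gives 4000 nM and compound 1 `O=C(/C(=C\c1ccc(Cl)cc1)S(=O)(=O)c1ccc(Br)cc1)c1ccc(Br)cc1` gives 50000 nM. The step of a 13-fold higher number from compound 2 to compound 1 (1.10 log units; beyond the scatter) goes with chloro in place of fluoro on an aromatic carbon. Compound 3 `Cc1ccsc1/C=C(/SCc1ccc(F)cc1)C(=O)c1ccc(Br)cc1` gives 50000 nM in this assay, level with compound 1 at the digits shown and sharing with it the highest number of the three; the difference between the core of compound 3 and that of compound 2 is not broken down here. Compound 4 `Cc1ccsc1/C=C(/SCc1ccc(Cl)cc1)C(=O)c1ccc(Br)cc1` carries the same change on the core of compound 3, (chloro in place of fluoro on an aromatic carbon), and has no value yet in this assay. Among the compounds with values here, for compound 3 the expected step of a 2.0-fold higher number from compound 3 to compound 4 (0.30 log units; within the scatter) rests on the rise seen with a 13-fold higher number from compound 2 to compound 1 (1.10 log units; beyond the scatter), with no second example to show that it carries over to the other core. Compound 4 is estimated at 100000 nM, between 40000 nM and 600000 nM.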

Compound 4, concentration for 50% growth inhibition: 25000 nM
Beside the measured number, compound 4's estimate is 4.0-fold (0.60 log units) above it; measured number below the stated range.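

On these two cores, chloro in place of fluoro on an aromatic carbon does not give the same result in this assay. On the core of compound 3, the step of a 2.0-fold lower number from compound 3 to compound 4 (0.30 log units; within the scatter) stays within the scatter, so the large rise seen on the other core does not carry over, and the two steps differ: the same change on two cores in this assay, a 13-fold higher number (1.10 log units; beyond the scatter) from compound 2 to compound 1 and a 2.0-fold lower number (0.30 log units; within the scatter) from compound 3 to compound 4, 25-fold (1.40 log units) apart, beyond the scatter of two such steps. With one pair on each core, this shows that a step read on one core cannot be assumed on the other in this series, but not which feature of the cores goes with the difference or how a further core would behave.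

Which of the several differences between the two cores matters remains open. So does whether a methoxy or an amine in place of the chloro would also give different steps on the two cores.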